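Cinnamamide series: moving from compound 2 to compound 4

The source may report more compounds than this note shows. Statements on the series, on what has been measured and on what is new or still open speak of the compounds shown alone.

Among the compounds with values here, compound 2 `COc1ccc(/C=C/C(=O)Nc2cc(C(=O)c3cc(OC)c(OC)c(OC)c3)ccc2OC)cc1` gives 10700 nM in a functional assay on HeLa cells (Homo sapiens) for cytotoxicity, read by MTT assay, with a stated time of 72 h (on this read-out lower numbers stand for stronger inhibition and higher numbers for weaker inhibition), the highest of the three numbers so far. Compound 1 `COc1ccc(C(=O)c2cc(OC)c(OC)c(OC)c2)cc1NC(=O)/C=C/c1ccc(OC)c(OC)c1` gives 7800 nM; the step of a 1.4-fold higher number from compound 1 to compound 2 (0.14 log units; within the scatter) stays within the scatter. Compound 3 `COc1cccc(/C=C/C(=O)Nc2cc(C(=O)c3cc(OC)c(OC)c(OC)c3)ccc2OC)c1` gives 3100 nM; the step of a 3.5-fold lower number from compound 2 to compound 3 (0.54 log units; beyond the scatter) and the step of a 2.5-fold lower number from compound 1 to compound 3 (0.40 log units; beyond the scatter) both lie beyond it. Compound 4 `COc1ccc(C(=O)c2cc(OC)c(OC)c(OC)c2)cc1NC(=O)/C=C/c1cccc(OC(F)(F)F)c1` differs from compound 2 in one place: 3-(trifluoromethoxy)phenyl in place of 4-methoxyphenyl on a double-bonded chain carbon bound to a double-bonded chain carbon. Within the data shown here, the step of a 3.5-fold lower number from compound 2 to compound 3 (0.54 log units; beyond the scatter) bears most directly on this change, as it also replaces the 4-methoxyphenyl on that chain carbon; no measured step shows trifluoromethoxy in place of methoxy. A modest lower number is therefore expected in this assay, a 2.7-fold lower number from compound 2 to compound 4 (0.43 log units; beyond the scatter), because a 3.5-fold lower number from compound 2 to compound 3 (0.54 log units; beyond the scatter). For compound 4 the estimate is 4000 nM, with a range of 1500 nM to 12000 nM.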

Compound 4, half-maximal inhibitory concentration: 7900 nM
For compound 4 the middle estimate is 2.0-fold (0.30 log units) below the measured one, and the stated range covers the measured number.
By their numbers in this assay, from the lowest: compound 3; then compounds 1, 4 and 2 (each within the scatter of the next).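

In this assay, trifluoromethyl in place of methyl on the oxygen gives up the lower number of compound 3 (a 2.5-fold higher number from compound 3 to compound 4 (0.41 log units; beyond the scatter)). The 3-(trifluoromethoxy)phenyl group does not separate from 4-methoxyphenyl (a 1.4-fold lower number from compound 2 to compound 4 (0.13 log units; within the scatter)) or from 3,4-dimethoxyphenyl (a 1.0-fold higher number from compound 1 to compound 4 (0.01 log units; within the scatter)), so at this chain carbon only compound 3 stands apart. No measurement on hand accounts for this loss.

Open, on these data alone, is whether an ethyl group in place of that methyl would keep the number of compound 3. Also open, as far as these compounds go, is how an amine on this aromatic ring would compare.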